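Carboxy to carboxyethyl: microsomal clearance notes

This account rests on a few compounds, and the source may have more. Where it says the series, first, only, none or still open, it means among the compounds named here.

Measured so far in an in vitro ADME assay on microsomes from liver (Rattus norvegicus) for metabolic stability, with a stated time of 30 min, tested at 1 uM; on this read-out higher numbers stand for fast clearance and lower numbers for slow clearance:
compound 1 `Cn1cc(C(=O)Nc2ccc(-c3ccccc3)c(C(F)(F)F)c2)c(=O)c2ccc(CCO)cc21` gives < 14 mL.min-1.g-1, a limit of the assay.
compound 2 `Cn1cc(C(=O)Nc2ccc(-c3ccccc3)c(C(F)(F)F)c2)c(=O)c2ccc(C(=O)O)cc21` gives < 14 mL.min-1.g-1, a limit of the assay.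

Compound 2 stands only at a limit in this assay, so no number is known for it. Compound 1 likewise sits at a limit. the limit of < 14 mL.min-1.g-1 in this assay, at which 2 of the 2 values shown sit, covers both values, so the step that the two limits leave unreadable from compound 1 to compound 2 cannot be read. Compound 3 `Cn1cc(C(=O)Nc2ccc(-c3ccccc3)c(C(F)(F)F)c2)c(=O)c2ccc(CCC(=O)O)cc21` differs from compound 2 by 2-carboxyethyl in place of carboxy on an aromatic carbon. Going by the values given here, only that unreadable step bears on the change, so no shift beyond the scatter is expected in this assay. Compound 3 is estimated at 10 mL.min-1.g-1, from 4 mL.min-1.g-1 to 25 mL.min-1.g-1. The expected step is a step that the limit leaves unreadable from compound 2 to compound 3, and a limit rather than a number is again likely.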

Compound 3, intrinsic clearance in microsomes: < 14 mL.min-1.g-1
Compound 3: only a limit was reported; the forecaster's own chance of this, stated with the estimate: 70%; the middle value lies beyond the limit too.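

No step among compound 1, compound 2 and compound 3 can be read in this assay, as all three stand only at a limit: the limit of < 14 mL.min-1.g-1 in this assay, at which 3 of the 3 values shown sit.

The compounds shown leave open whether 2-hydroxyethyl, carboxy and 2-carboxyethyl differ at all in intrinsic clearance in microsomes.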